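Benzyl Replaces Trimethoxyphenyl on the Amine Nitrogen

A few compounds are considered here, and "the series" means these few. Any claim that something is new, unique, unknown or untested is made for them only; others in the source may bear on it.

Going by the values given here, compound 2 `COc1cc(N/C(CCNC2=CC(=O)c3ccccc3C2=O)=N\S(=O)(=O)c2ccc(C)cc2)cc(OC)c1OC` gives 3390 nM in a functional assay on HeLa cells (Homo sapiens) for cytotoxicity, read by MTT assay, with a stated time of 48 h (on this read-out higher numbers stand for weaker inhibition and lower numbers for stronger inhibition), the lowest of the two numbers measured so far. Its nearest neighbour is compound 1 `Cc1ccc(S(=O)(=O)/N=C(/CCNC2=CC(=O)c3ccccc3C2=O)Nc2ccccc2I)cc1`, which in this assay gives 19100 nM. Among the compounds with values here, the only step recorded, a 5.6-fold lower number from compound 1 to compound 2 (0.75 log units; beyond the scatter), shows that exchanging the aryl group on the amine nitrogen moves the number beyond the scatter.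

Compound 3 `Cc1ccc(S(=O)(=O)/N=C(/CCNC2=CC(=O)c3ccccc3C2=O)NCc2ccccc2)cc1` has not yet been measured in this assay. It differs from compound 2 in one place: benzyl in place of 3,4,5-trimethoxyphenyl on an amine nitrogen. Within the data shown here, that single recorded step bears on the same position, and it was modest in size, but it compared two aryl groups, whereas benzyl is represented by no measured compound. The direction of the new step therefore cannot be read from the data, only its likely size. Compound 3 is expected to give 8000 nM in this assay, with a range from 2500 nM to 30000 nM. The estimated step of a 2.4-fold higher number from compound 2 to compound 3 (0.37 log units; beyond the scatter) is accordingly expected to be modest, with the uncertainty spread wide in both directions.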

Compound 3, half-maximal inhibitory concentration: 3980 nM
Compound 3: the middle estimate sits 2.0-fold (0.30 log units) above what was measured, within the range that was stated.
By their numbers in this assay, from the lowest: compounds 2 and 3 (each within the scatter of the next); then compound 1.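

In this assay, the step of a 1.2-fold higher number from compound 2 to compound 3 (0.07 log units; within the scatter) shows that benzyl, with 7 heavy atoms and 0 hydrogen-bond acceptors, cannot be told apart from 3,4,5-trimethoxyphenyl, with 12 heavy atoms and 3 hydrogen-bond acceptors, on this amine nitrogen. The second new step, a 4.8-fold lower number from compound 1 to compound 3 (0.68 log units; beyond the scatter) for benzyl in place of 2-iodophenyl, lies beyond the scatter, so compound 1 now stands apart from two different groups at this place, and an aryl group bound directly to the nitrogen is not needed to reach the lower numbers seen here. No measurement bearing on why these groups behave as they do is available.

The compounds shown leave open whether the higher number of compound 1 belongs to the iodine atom or to the 2-iodophenyl group as a whole, a question that a plain phenyl on the same nitrogen would address. They also leave open how far this tolerance extends, for instance to a longer chain such as 2-phenylethyl or to a small group such as methyl, and whether it holds with the rest of the molecule changed.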